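Capping the hydroxyl of a potent vasopressin agonist

This account rests on a few compounds, and the source may have more. Where it says the series, first, only, none or still open, it means among the compounds named here.

Compound 1 `Cc1cc(C(=O)N2CCCCc3ccccc32)ccc1CNC(=O)N1CCC[C@@H]1C(=O)N(C)C` gives 380 nM in a functional assay on HEK293 cells for agonist activity at Vasopressin V2 receptor (Homo sapiens), read by a luciferase reporter and cAMP accumulation; a higher number here means that more compound is needed for the effect, a lower number that less compound is needed.
Compound 2 `Cc1cc(C(=O)N2CCCCc3ccccc32)ccc1CNC(=O)N1C[C@H](O)C[C@H]1C(=O)N(C)C` gives 2.3 nM in this assay.

Compound 2 stands at the lowest of the two numbers; its nearest neighbour is compound 1, and the step of a 170-fold lower number from compound 1 to compound 2 (2.22 log units; beyond the scatter) is the only measured one here. Compound 3 `Cc1cc(C(=O)N2CCCCc3ccccc32)ccc1CNC(=O)N1C[C@H](OC(C)(C)C)C[C@H]1C(=O)N(C)C` differs from compound 2 by tert-butyl in place of hydrogen on an oxygen on a saturated carbon; cut one bond further out, this reads hydroxy to tert-butoxy, so the hydrogen-bond donor that entered between compound 1 and compound 2 is lost again. Among the compounds with values here, that step is the only measured guide, and it shows the hydroxy group carried a large gain in this assay. Compound 3 is therefore expected to move back toward compound 1, though not necessarily all the way, since the oxygen itself stays in place. Compound 3 is estimated at 40 nM, with a range from 5 nM to 400 nM. The expected step is a 17-fold higher number from compound 2 to compound 3 (1.24 log units; beyond the scatter).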

Compound 3, half-maximal effective concentration: 46 nM
For compound 3 the middle estimate is 1.2-fold (0.06 log units) below the measured one; the measured number falls inside the stated range.
By their numbers in this assay, from the lowest: compound 2; then compound 3; then compound 1.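

In this assay, replacing the hydrogen on this oxygen with tert-butyl gives back much of the earlier gain, with a 20-fold higher number from compound 2 to compound 3 (1.30 log units; beyond the scatter) for this change. The loss is only partial: compound 3 at 46 nM still has a lower number than compound 1 at 380 nM and so needs less compound for the effect, which shows that this place accepts a capped oxygen to some degree. Nothing measured here explains why the numbers move this way.

The compounds shown cannot separate the loss of the hydroxy hydrogen from the arrival of four carbons. Going by these compounds, a methoxy group would carry a much smaller cap on the same oxygen, and an amine in place of the hydroxy group would test a different atom at this place, so both remain open questions.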